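Replacing an isopropyl with a longer ester-bearing chain

This account rests on a few compounds, and the source may have more. Where it says the series, first, only, none or still open, it means among the compounds named here.

In a functional assay on the whole organism (Tail, strain ICR) with Mus musculus as the target, in the tail flick test, with a stated time of 30 min, at a dose of 25 umol/kg by the oral route (a higher number here means a stronger effect of the compound at the dose given, a lower number a weaker effect), compound 1 `CC(C)[C@H](NC(=O)CN(c1ncnc2c1ncn2C1CCCCO1)C1CC1)C(=O)OCc1ccccc1` gives 21.8%, the lowest of the three numbers. It sits within the scatter of compound 3 `NC(=O)CC[C@H](NC(=O)CN(c1nc(Cl)nc2[nH]cnc12)C1CC1)C(=O)OCc1ccccc1`, which gives 30.8%, and well below compound 2 `O=C(CN(c1nc(Cl)nc2[nH]cnc12)C1CC1)N[C@@H](CCC(=O)OCc1ccccc1)C(=O)OCc1ccccc1`, which gives 52.8%. Compound 4 `O=C(CN(c1ncnc2c1ncn2C1CCCCO1)C1CC1)N[C@@H](CCC(=O)OCc1ccccc1)C(=O)OCc1ccccc1` differs from compound 1 in one place: 2-(benzyloxycarbonyl)ethyl in place of isopropyl on a saturated chain carbon bound to an amide-type nitrogen and a carbonyl carbon. Within the data shown here, no measured step shows this exact change. Among the measured compounds shown here, the only measured step, a number 22 percentage points lower from compound 2 to compound 3 (beyond the scatter), involves removing the same benzyloxy part from a carbonyl carbon and lowered this assay; compound 4 carries that part while compound 1 does not, and compound 4 shares its side chain with compound 2. The expected step of a number 18.2 percentage points higher from compound 1 to compound 4 (beyond the scatter) is therefore upward, beyond the scatter. Compound 4 is estimated at 40%, between 20% and 60%.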

Compound 4, a percentage reported as activity, at one dose (the size of the read-out at that dose, not a potency): 32.6%
Beside the measured number, compound 4's estimate is 7.4 percentage points above it; low and high end bracket the measured number.
By their numbers in this assay, from the lowest: compounds 1, 3 and 4 (each within the scatter of the next, the first and the last beyond it); then compound 2.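

Among these compounds, on the saturated chain carbon bound to an amide-type nitrogen and a carbonyl carbon, the earlier compounds offered no direct comparison. In this assay the swap to 2-(benzyloxycarbonyl)ethyl gives a number 10.8 percentage points higher from compound 1 to compound 4 (beyond the scatter), so this position can carry the larger group, with its aromatic ring, and the effect rises modestly. Nothing available explains the rise.

As far as these compounds go, whether the rise comes from the benzyloxycarbonyl end or simply from chain length remains open. A carboxylic acid at the end of the same chain, or a longer plain alkyl chain, would help separate the two.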